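A Methyl Group on the Anilide Ring

A few compounds are considered here, and "the series" means these few. Any claim that something is new, unique, unknown or untested is made for them only; others in the source may bear on it.

Measured compounds:
compound 1 `O=C(CCC(=O)OCCCCCCSc1ccc([N+](=O)[O-])c2nonc12)Nc1ccccc1` — 700 nM
compound 2 `O=C(CCC(=O)OCCCCCCSc1ccc([N+](=O)[O-])c2nonc12)Nc1ccc(F)cc1` — 320 nM

In an assay on isolated protein for inhibition of glutathione S-transferase Mu 2 (Homo sapiens), with a stated time of 10 min (on this read-out lower numbers stand for stronger inhibition and higher numbers for weaker inhibition), compound 1 gives 700 nM, the highest of the two numbers; its nearest neighbour compound 2 gives 320 nM. Going by the values given here, the only measured step, a 2.2-fold lower number from compound 1 to compound 2 (0.34 log units; beyond the scatter), is a modest one. Compound 3 `Cc1ccc(NC(=O)CCC(=O)OCCCCCCSc2ccc([N+](=O)[O-])c3nonc23)cc1` differs from compound 1 by methyl in place of hydrogen on an aromatic carbon. Among the compounds with values here, no measured step puts a methyl group at this place, so the fluoro step is only a loose guide. Compound 3 is expected to lie close to compound 1 in this assay, with a step of a 1.4-fold lower number from compound 1 to compound 3 (0.15 log units; within the scatter) at most. The estimate for compound 3 is 500 nM, within 250 nM to 1000 nM.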

Compound 3, half-maximal inhibitory concentration: 390 nM
The estimate for compound 3 lay 1.3-fold (0.11 log units) above the measured number, and the stated range covers the measured number.
By their numbers in this assay, from the lowest: compounds 2, 3 and 1 (each within the scatter of the next, the first and the last beyond it).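

Putting methyl at this place gives a 1.8-fold lower number from compound 1 to compound 3 (0.25 log units; within the scatter), so the methyl group cannot be told apart from hydrogen here. Exchanging methyl for fluoro gives a 1.2-fold higher number from compound 2 to compound 3 (0.09 log units; within the scatter), so these two groups cannot be told apart either, even though only the fluoro compound stands beyond the scatter from the unsubstituted compound. No measurement here offers an explanation for these results. Still open, from the compounds shown here alone, is how a chloro, methoxy or amino group at this place would read, and whether a longer carbon chain would produce a step beyond the scatter.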